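Series notes: amide for acid at the piperidine carbon

The compounds below may be only part of what the source reports. "The series", "measured", "known", "first", "only" and "open" are said of these compounds alone.

Compound 2 `COc1ccc(/C=C\c2cc(OC)c(OC)c(OC)c2)cc1OCc1ccc(CN2CCCC[C@@H]2C(=O)O)cc1` is a limit, not a number: in a functional assay on HeLa cells (Homo sapiens) for antiproliferative activity, read by CCK-8 assay, with a stated time of 48 h (a lower number here means a stronger inhibitor, a higher number a weaker inhibitor), compound 2 gives > 10000 nM. Compound 1 `COc1ccc(/C=C\c2cc(OC)c(OC)c(OC)c2)cc1OCc1ccc(CN2C[C@H](O)C[C@@H]2C(=O)O)cc1` also rests at a limit, giving > 10000 nM in this assay, so the step that the two limits leave unreadable from compound 1 to compound 2 cannot be sized (the limit of > 10000 nM in this assay, at which 2 of the 2 values shown sit). Compound 3 `COc1ccc(/C=C\c2cc(OC)c(OC)c(OC)c2)cc1OCc1ccc(CN2CCCCC2C(=O)NCCN)cc1` differs from compound 2 by 2-((2-aminoethyl)carbamoyl)piperidin-1-yl in place of 2-carboxypiperidin-1-yl on a saturated chain carbon bound to an aromatic carbon. Going by the values given here, no measured step bears on this change. The expected step of an at least 1.2-fold lower number from compound 2 to compound 3 (0.09 log units; that floor lies within the scatter) is accordingly uncertain, and compound 3 is estimated at 8000 nM in this assay, within 1000 nM to 50000 nM, with a fair chance of a limit again.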

Compound 3, half-maximal inhibitory concentration: 7300 nM
Beside the measured number, compound 3's estimate is 1.1-fold (0.04 log units) above it, and the stated range covers the measured number.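

In this assay, going by these compounds alone, the 2-((2-aminoethyl)carbamoyl)piperidin-1-yl group at this saturated chain carbon gives the only number so far rather than a limit, with an at least 1.3-fold lower number from compound 2 to compound 3 (0.13 log units; that floor lies within the scatter) and an at least 1.3-fold lower number from compound 1 to compound 3 (0.13 log units; that floor lies within the scatter). Both steps are floors, so their true size stays unfixed, and the step between the two limits cannot be read. The series still rests mostly at a limit: the limit of > 10000 nM in this assay, at which 2 of the 3 values shown sit.

Whether the amide alone or the amine of the aminoethyl chain accounts for the step remains open. A plain primary carboxamide and a longer chain ending in an amine would separate the two.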